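Series notes: from compound 1 to compound 4

The source may report more compounds than this note shows. Statements on the series, on what has been measured and on what is new or still open speak of the compounds shown alone.

The shared core carries a chain on a double-bonded nitrogen, and the compounds differ only in that chain. Compound 1 `Nc1n/c(=N\CCCCc2ccccc2)nc(N)c2c1ncn2Cc1ccccc1` carries phenyl on a saturated chain carbon, four bonds along the chain from the double-bonded nitrogen. In a functional assay on PC-3 cells (Homo sapiens) for antiproliferative activity, read by WST assay, with a stated time of 72 h (a lower number here means a stronger inhibitor, a higher number a weaker inhibitor), compound 1 gives > 75000 nM, which is a limit of the assay and not a number. Where compound 1 stands is therefore set only by that limit (the limit of > 75000 nM in this assay, at which 1 of the 3 values shown sits). Compound 3 `CCCCCCCCCC/N=c1\nc(N)c2ncn(Cc3ccccc3)c2c(N)n1` gives 5150 nM in this assay, and compound 2 `CCCCCCCCCCCCCCCCCC/N=c1\nc(N)c2ncn(Cc3ccccc3)c2c(N)n1` gives 5450 nM.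

The step to the unmeasured compound 4 `CCCCCCCC/N=c1\nc(N)c2ncn(Cc3ccccc3)c2c(N)n1` is butyl in place of phenyl on a saturated chain carbon, four bonds along the chain from a double-bonded nitrogen. Among the measured compounds shown here, two measured steps bear on it. The closest is an at least 14-fold lower number from compound 1 to compound 3 (1.16 log units; beyond the scatter), the same kind of replacement at the same place, with a longer alkyl chain entering. The other is a 1.1-fold lower number from compound 2 to compound 3 (0.02 log units; within the scatter), which shows that adding octyl far out along the chain changes nothing within the scatter. For the measured compounds named here, no measured pair shows whether a chain shorter than that of compound 3 behaves the same way, but the two alkyl members sit together, so a step in this assay toward a lower number, of about the size seen between compound 1 and compound 3, is expected. The step from compound 1 to compound 4 is expected to be an at least 12-fold lower number from compound 1 to compound 4 (1.09 log units; beyond the scatter). Compound 4 is estimated at 6000 nM, with a range from 2500 nM to 15000 nM.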

Compound 4, half-maximal inhibitory concentration: 5930 nM
For compound 4 the middle estimate is 1.0-fold (0.01 log units) above the measured one; the range from low to high includes it.
By their numbers in this assay, from the lowest: compounds 3, 2 and 4 (each within the scatter of the next). At a limit, above all of these: compound 1.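

Butyl in place of phenyl, on a saturated chain carbon four bonds along the chain from a double-bonded nitrogen, gives an at least 12-fold lower number from compound 1 to compound 4 (1.10 log units; beyond the scatter) in this assay, so a second alkyl chain now stands against the phenyl-ended chain and the earlier step at this place no longer rests on a single pair. Going by these compounds, the reading for compound 1 is a limit of the assay and not a number, so the true size of this step stays unknown: the limit of > 75000 nM in this assay, at which 1 of the 4 values shown sits. Hydrogen in place of ethyl, eight bonds along the chain, gives a 1.2-fold higher number from compound 3 to compound 4 (0.06 log units; within the scatter), and hydrogen in place of decyl at that same place gives a 1.1-fold higher number from compound 2 to compound 4 (0.04 log units; within the scatter), so the three alkyl members read alike in this assay, with no trend in chain length among them.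

On these data alone, whether a chain much shorter than that of compound 4 stays at the same level remains open, as does whether a terminal amine or carboxylic acid on the alkyl chain would change the reading. Also open, as far as these compounds go, is whether cyclohexyl in place of phenyl would read like the alkyl members or like compound 1.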